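This account rests on a few compounds, and the source may have more. Where it says the series, first, only, none or still open, it means among the compounds named here.

Compound 2 `COc1ccc(COc2ccc3c(Cn4ccnc4)cc(=O)oc3c2)cc1` and compound 1 `O=c1cc(Cn2ccnc2)c2ccc(OCc3cccc(Cl)c3)cc2o1` share one core and differ only in the group on the saturated chain carbon bound to an oxygen on the aromatic ring. In an assay on V79MZh11B1 cells for inhibition of cytochrome P450 11B1, mitochondrial (Homo sapiens), read by HPLC, with a stated time of 25 min (a lower number here means a stronger inhibitor, a higher number a weaker inhibitor), compound 1 gives 31 nM, while compound 2 gives 80 nM. Among the measured compounds shown here, the change a 2.6-fold higher number from compound 1 to compound 2 (0.41 log units; beyond the scatter) is the only step measured here, and it leaves compound 2 with the highest of the two numbers, which means the weaker inhibitor of the pair.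

Compound 3 `CC(C)Oc1ccc(COc2ccc3c(Cn4ccnc4)cc(=O)oc3c2)cc1` is not yet measured. It differs from compound 2 by isopropyl in place of methyl on an oxygen on an aromatic ring. For the measured compounds named here, no measured step touches this position: the single known step replaces one whole aromatic group by another, not a small group on the oxygen, so it gives no direct guide to what an isopropyl in place of a methyl does in this assay. With nothing to point either way, the expected change is small, likely within the usual scatter, and the estimate a 1.1-fold higher number from compound 2 to compound 3 (0.05 log units; within the scatter) reflects that.

On this basis compound 3 is expected to give about 90 nM in this assay, with a range from 30 nM to 270 nM.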

Compound 3, half-maximal inhibitory concentration: 48 nM
Compound 3: middle estimate off by 1.9-fold (0.27 log units), on the high side, and the stated range covers the measured number.
By their numbers in this assay, from the lowest: compounds 1, 3 and 2 (each within the scatter of the next, the first and the last beyond it).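

In this assay, isopropyl in place of methyl on an oxygen on an aromatic ring gives a 1.7-fold lower number from compound 2 to compound 3 (0.22 log units; within the scatter), so the group on this oxygen can grow from methyl to isopropyl, from 1 heavy atom to 3, without a shift that stands out from the ordinary spread of repeat measurements. Among the compounds shown here, this is the first reading at this oxygen, as the earlier step exchanged one whole aromatic group for another and could say nothing about a change confined to the group on the oxygen. Nothing available here offers an explanation for this result, whether from structures of the bound compounds or from any other kind of measurement.

Methyl and isopropyl are the only two groups shown on this oxygen, so it remains open how far this tolerance extends, for instance to a longer chain such as hexyl, or to a chain ending in an amine or a carboxylic acid. Also open, from the compounds shown here alone, is what a plain hydroxyl would do in place of the methoxy, and whether the change from methoxy to isopropoxy would read the same on a different core.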